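The compounds below may be only part of what the source reports. "The series", "measured", "known", "first", "only" and "open" are said of these compounds alone.

Working notes on the series. Compound 1 `CC1CN(C(N)=S)N=C1c1ccccc1` is the parent, with hydrogen on the amide-type nitrogen. In an ADME assay on KB cells (Homo sapiens) for cytotoxicity, read by MTT assay, with a stated time of 44 h (on this read-out lower numbers stand for stronger inhibition and higher numbers for weaker inhibition), compound 1 gives > 100000 nM, which is a limit of the assay and not a number. Compound 2 `CC(C)CNC(=S)N1CC(C)C(c2ccccc2)=N1` gives in this assay > 100000 nM, also a limit. Compound 3 `CC1CN(C(=S)NC2CCCC2)N=C1c1ccccc1` gives in this assay > 100000 nM, again a limit. The steps from compound 1 to compound 2 a step that the two limits leave unreadable from compound 1 to compound 2 and from compound 1 to compound 3 a step that the two limits leave unreadable from compound 1 to compound 3 cannot be read because of the limit of > 100000 nM in this assay, at which 3 of the 3 values shown sit; the same holds for the step from compound 2 to compound 3 a step that the two limits leave unreadable from compound 2 to compound 3. Among the compounds with values here, no measured step therefore gives a readable size for the effect of a group on that nitrogen.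

Compound 4 `Cc1ccccc1NC(=S)N1CC(C)C(c2ccccc2)=N1` differs from compound 1 by 2-methylphenyl in place of hydrogen on an amide-type nitrogen. The measured substitutions on the same nitrogen left every value at the limit, so no change beyond the scatter is expected in this assay. The step from compound 1 to compound 4 is estimated as a step that the limit leaves unreadable from compound 1 to compound 4. Compound 4 is expected to give 150000 nM in this assay, within 40000 nM to 600000 nM, most likely again as a limit.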

Compound 4, half-maximal inhibitory concentration: > 100000 nM
Compound 4 was reported as a limit (the forecaster's own chance of this, stated with the estimate: 80%); the middle value does not contradict the limit.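

The steps from compound 1, compound 2 and compound 3 to compound 4 cannot be read, for one reason: the limit of > 100000 nM in this assay, at which 4 of the 4 values shown sit.

The compounds shown leave open whether any group on the amide-type nitrogen changes the read-out in this assay, and by how much.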